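Acid to methylamide at the carbonyl of the shared core

The source may hold more compounds than are shown below. What is called first, only, known or untested is meant among the compounds shown, and "the series" means these compounds.

Compound 3 `C[C@@H](Nc1c(C(=O)O)cnc2ccc(-c3cccnc3)cc12)c1ccc(Cl)cc1` sits at the floor of what has been measured: in an assay on HT-29 cells for inhibition of Serine-protein kinase ATM (Homo sapiens), read by fluorescence, with a stated time of 1 h (on this read-out lower numbers stand for stronger inhibition and higher numbers for weaker inhibition), compound 3 gives only a limit, > 30000 nM. Compound 2 `C[C@@H](Nc1ccnc2ccc(-c3cccnc3)cc12)c1ccc(Cl)cc1` likewise gives a limit, > 30000 nM, in this assay. Within the data shown here, compound 1 `C[C@@H](Nc1c(C(N)=O)cnc2ccc(-c3cccnc3)cc12)c1ccc(Cl)cc1` is the only member with a number, 109 nM. The limit of > 30000 nM in this assay, at which 2 of the 3 values shown sit, thus holds two of the three values, and the step that the two limits leave unreadable from compound 2 to compound 3 cannot be read. Compound 4 `CNC(=O)c1cnc2ccc(-c3cccnc3)cc2c1N[C@H](C)c1ccc(Cl)cc1` differs from compound 3 by methylamino in place of hydroxy on a carbonyl carbon. The measured step that bears on this is an at least 270-fold higher number from compound 1 to compound 3 (2.43 log units; beyond the scatter), where the carbonyl bearing an amino group gave a number and the carboxy gave only a limit; the step of an at least 270-fold higher number from compound 1 to compound 2 (2.43 log units; beyond the scatter) shows that the carbamoyl group itself carries this potency. Taking compound 4 as a carbonyl bearing a substituted amino group, a large step downward in this assay is expected from compound 3 to compound 4, an at least 50-fold lower number from compound 3 to compound 4 (1.69 log units; beyond the scatter), though a methylcarbamoyl has no measured precedent here. Compound 4 is estimated at 600 nM, within 100 nM to 6000 nM.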

Compound 4, half-maximal inhibitory concentration: > 30000 nM
Compound 4 was reported as a limit (the forecaster's own chance of this, stated with the estimate: 10%); middle value at least 50-fold (1.69 log units) away from the limit.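

In this assay, methyl in place of hydrogen on an amide-type nitrogen gives an at least 270-fold higher number from compound 1 to compound 4 (2.43 log units; beyond the scatter), so this small change at the carbamoyl group is enough to lose the measured number. The earlier compounds shown here tied the number to the carbamoyl group against hydrogen and carboxy; compound 4 shows that a carbonyl bearing a substituted amino group does not by itself keep it, and among the four compounds only compound 1 gives a number. The steps among compound 2, compound 3 and compound 4 cannot be read, and the values of these three compounds are limits: the limit of > 30000 nM in this assay, at which 3 of the 4 values shown sit.

Going by these compounds, whether any other group on this nitrogen keeps a number remains open, for example ethyl, hydroxy or methoxy. Also open, on these data alone, is how a nitrile or a dimethylcarbamoyl group in place of the carbamoyl group would read out.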